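Moving one chlorine on a compound at the assay limit

The source may hold more compounds than are shown below. What is called first, only, known or untested is meant among the compounds shown, and "the series" means these compounds.

Compound 1 (`O=C(CCl)Nc1ccc(C(=O)/C=C/c2ccc(Cl)cc2)cc1`): 8160 nM
Compound 2 (`COc1cccc(/C=C/C(=O)c2ccc(NC(=O)CCl)cc2)c1`): 10300 nM
Compound 3 (`O=C(CSC(=S)N[C@H]1CCOC1=O)Nc1ccc(C(=O)/C=C/c2ccc(Cl)cc2)cc1`): > 128000 nM (a limit, not a number)

In a functional assay on SMMC-7721 cells (Homo sapiens) for cytotoxicity, read by MTT assay, with a stated time of 72 h (on this read-out lower numbers stand for stronger inhibition and higher numbers for weaker inhibition), compound 3 sits at a limit of the assay (> 128000 nM) rather than at a number. Compound 4 (`O=C(CSC(=S)N[C@H]1CCOC1=O)Nc1ccc(C(=O)/C=C/c2ccccc2Cl)cc1`) has the same atoms as compound 3, joined differently (2-chlorophenyl in place of 4-chlorophenyl on a double-bonded chain carbon bound to a double-bonded chain carbon). For the measured compounds named here, the one measured step that bears on this is large (an at least 15-fold higher number from compound 1 to compound 3 (1.19 log units; beyond the scatter)), and it brought in the group that compound 4 keeps. Going by the values given here, no measured step moves the chlorine on the phenyl, so no shift beyond the scatter is expected in this assay on this change. The estimated step is a step that the limit leaves unreadable from compound 3 to compound 4. Compound 4 is estimated at 150000 nM (expected range 50000 nM to 450000 nM).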

Compound 4, half-maximal inhibitory concentration: 20400 nM
Estimate against measurement, compound 4: 7.4-fold (0.87 log units) above, outside the stated range (below it).
By their numbers in this assay, from the lowest: compounds 1, 2 and 4 (each within the scatter of the next, the first and the last beyond it). At a limit, above all of these: compound 3.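

Putting 2-chlorophenyl in place of 4-chlorophenyl gives an at least 6.2-fold lower number from compound 3 to compound 4 (0.79 log units; beyond the scatter) and shows that the place of this one chlorine matters in this series. Compound 4 keeps the large group carrying the five-membered ring and still gives a readable number, so that group alone does not fix the result at the limit. The full size of the step cannot be read because compound 3 sits at a limit: the limit of > 128000 nM in this assay, at which 1 of the 4 values shown sits.

Why the chlorine's place matters stays unknown. Also open, as far as these compounds go, is whether an amine or a carboxylic acid in place of this chlorine would give a similar number.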